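Chain length series: from compound 3 to compound 4

A few compounds are considered here, and "the series" means these few. Any claim that something is new, unique, unknown or untested is made for them only; others in the source may bear on it.

Values in an ADME assay on Vero cells (Chlorocebus sabaeus) for cytotoxicity (on this read-out lower numbers stand for higher toxicity in this test and higher numbers for lower toxicity in this test), by compound:
- compound 1 `CCCCCC(=O)Nc1nc(N)nc2c1ncn2[C@H]1CO[C@@H](CO)O1` gives > 100000 nM as a limit of the assay
- compound 2 `CCCCCCCCCCCC(=O)Nc1nc(N)nc2c1ncn2[C@H]1CO[C@@H](CO)O1` gives 53000 nM
- compound 3 `CCCCCCCCCCCCCC(=O)Nc1nc(N)nc2c1ncn2[C@H]1CO[C@@H](CO)O1` gives 7700 nM

Compound 3 holds the lower of the two actual numbers, with compound 2 as its nearest neighbour. The next structure is compound 4 `CCCCCCCC/C=C\CCCCCCCC(=O)Nc1nc(N)nc2c1ncn2[C@H]1CO[C@@H](CO)O1` and its change from compound 3 reads dec-1-en-1-yl in place of hexyl on a saturated chain carbon, seven bonds along the chain from a carbonyl carbon in words: dec-1-en-1-yl in place of hexyl on a saturated chain carbon, seven bonds along the chain from a carbonyl carbon.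

Among the compounds with values here, three measured steps bear on this change. The longer reach from the shortest chain is large (an at least 12-fold lower number from compound 1 to compound 3 (1.11 log units; beyond the scatter)), while the first extension is only a floor within the scatter (an at least 1.8-fold lower number from compound 1 to compound 2 (0.27 log units; that floor lies within the scatter)). Across these three compounds a longer chain goes with a lower number, and none goes against it. Within the data shown here, the double bond in the entering chain has no counterpart among the measured compounds, so the extrapolation is loose. The closest guide is a modest step (a 6.9-fold lower number from compound 2 to compound 3 (0.84 log units; beyond the scatter)), so a further move to a lower number is expected in this assay rather than a flat result. The expected step is modest (a 2.6-fold lower number from compound 3 to compound 4 (0.41 log units; beyond the scatter)). For compound 4 the estimated value is 3000 nM with an expected range from 700 nM to 20000 nM as the working span.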

Compound 4, half-maximal cytotoxic concentration: 19000 nM
Compound 4: middle estimate off by 6.3-fold (0.80 log units), on the low side, and the stated range covers the measured number.
By their numbers in this assay, from the lowest: compound 3; then compound 4; then compound 2. At a limit, above all of these: compound 1.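

The fall in number that ran with chain length through compound 3 does not continue at this position in this assay: although dec-1-en-1-yl carries more carbon than the hexyl it replaces, the change gives a 2.5-fold higher number from compound 3 to compound 4 (0.39 log units; beyond the scatter), so compound 4 goes against the order of the three earlier compounds, while part of the fall remains, with a 2.8-fold lower number from compound 2 to compound 4 (0.45 log units; beyond the scatter). Measured from the shortest chain, the change to dodec-3-en-1-yl still gives an at least 5.2-fold lower number from compound 1 to compound 4 (0.72 log units; beyond the scatter). Compound 1 stands at a limit of the assay and not at a number, so that last step is only a floor: the limit of > 100000 nM in this assay, at which 1 of the 4 values shown sits.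

From the compounds shown here alone, it remains open whether the higher number of compound 4 goes with the double bond itself or with the chain as a whole; a fully saturated chain with the same carbons would separate the two. Also open, going by these compounds, is whether the geometry of the double bond matters, as the trans form of the same chain would show in this assay.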